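Sulfonamide-to-amide swap on the aminoalkyl side chain

The source may report more compounds than this note shows. Statements on the series, on what has been measured and on what is new or still open speak of the compounds shown alone.

Measured compounds in a functional assay on A-375 cells (Homo sapiens) for cytotoxicity, read by MTT assay; on this read-out lower numbers stand for stronger inhibition and higher numbers for weaker inhibition:
- compound 1 `O=C(NCCNc1nccc(-c2c(-c3cccc(F)c3)nc3sccn23)n1)c1c(F)cccc1F`: compound 1 gives 2700 nM
- compound 2 `O=S(=O)(NCCCNc1nccc(-c2c(-c3cccc(F)c3)nc3sccn23)n1)c1ccc(Cl)cc1`: compound 2 gives 5900 nM

Among the compounds with values here, compound 2 stands as the higher of the two numbers so far; the one measured step, a 2.2-fold higher number from compound 1 to compound 2 (0.34 log units; beyond the scatter), changes both the chain length and the aryl-bearing group at once.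

Compound 3 `O=C(NCCNc1nccc(-c2c(-c3cccc(F)c3)nc3sccn23)n1)c1ccc(Cl)cc1` is the next member. Relative to compound 2 the change is ((4-chlorophenyl)carbonyl)amino in place of (((4-chlorophenyl)sulfonyl)amino)methyl on a saturated chain carbon, two bonds along the chain from a nitrogen on an aromatic ring. Compound 3 thus keeps the aryl group of compound 2 but returns to the chain and the carbonyl link of compound 1, so it sits between the two measured compounds and undoes part of the step from compound 1 to compound 2. Within the data shown here, only that step bears on the question, and it was modest; since it bundles two changes, how much of it belongs to the chain and carbonyl versus the aryl group cannot be separated from the numbers in hand.

Expected, then, is a modest decrease, a 1.7-fold lower number from compound 2 to compound 3 (0.23 log units; within the scatter), landing compound 3 near compound 1. The estimate for compound 3 in this assay is 3500 nM, with a range from 1500 nM to 8000 nM.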

Compound 3, half-maximal inhibitory concentration: 2570 nM
Beside the measured number, compound 3's estimate is 1.4-fold (0.13 log units) above it; the measured number falls inside the stated range.
By their numbers in this assay, from the lowest: compounds 3 and 1 (each within the scatter of the next); then compound 2.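

In this assay, 4-chlorophenyl in place of 2,6-difluorophenyl on a carbonyl carbon gives no separation between the two aryl groups (a 1.1-fold lower number from compound 1 to compound 3 (0.02 log units; within the scatter)), so this aryl change does not shift the number on the chain and carbonyl link of compound 1. With 4-chlorophenyl held constant, ((4-chlorophenyl)carbonyl)amino in place of (((4-chlorophenyl)sulfonyl)amino)methyl on a saturated chain carbon, two bonds along the chain from a nitrogen on an aromatic ring, gives a step beyond the scatter (a 2.3-fold lower number from compound 2 to compound 3 (0.36 log units; beyond the scatter)), which places the earlier difference with the chain and link rather than with the aryl group. No measurement here explains why this change moves the number.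

The chain and link changes remain coupled, so their separate contributions cannot be read; a sulfonyl link on the chain of compound 3, or a carbonyl link on the chain of compound 2, would separate them. Also open, from the compounds shown here alone, is how a urea link, a longer chain, or a terminal amine or carboxylic acid in place of the aryl group would behave at this position.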